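Swapping a methyl for fluorine on the pyridinyl ether

A few compounds are considered here, and "the series" means these few. Any claim that something is new, unique, unknown or untested is made for them only; others in the source may bear on it.

Compound 3 `Cc1ccc(C)c(Oc2ccc3nc(COc4cccc(C(=O)O)c4)n(C)c3c2)n1` carries a shared core with a 3,6-dimethylpyridin-2-yl group on an oxygen on an aromatic ring. In a physicochemical assay for lipophilicity, read by LC-MS, in phosphate buffer, measured as octanol-water partition, with a stated time of 30 min, at pH 7.4, tested at 200 mM (a lower number here means a more polar compound, a higher number a more lipophilic compound), compound 3 gives 1.4, the highest of the three numbers in hand. Compound 1 `Cn1c(COc2cccc(C(=O)O)c2)nc2ccc(Oc3cccc(Cl)n3)cc21` gives 1.2 in this assay, and compound 2 `Cc1ccnc(Oc2ccc3nc(COc4cccc(C(=O)O)c4)n(C)c3c2)c1` gives 0.8; the step of a number 0.20 log units higher from compound 1 to compound 3 (within the scatter) lies within the scatter, while the step of a number 0.60 log units higher from compound 2 to compound 3 (beyond the scatter) lies beyond it. Compound 4 `Cc1cc(F)cnc1Oc1ccc2nc(COc3cccc(C(=O)O)c3)n(C)c2c1` has not yet been measured in this assay. Its difference from compound 3 is 5-fluoro-3-methylpyridin-2-yl in place of 3,6-dimethylpyridin-2-yl on an oxygen on an aromatic ring. The measured steps that bear on it are a number 0.60 log units higher from compound 2 to compound 3 (beyond the scatter) and a number 0.40 log units lower from compound 1 to compound 2 (beyond the scatter), each a modest change at this same position, and a number 0.20 log units higher from compound 1 to compound 3 (within the scatter), which stayed within the scatter. Taking these as a guide, a modest downward step is expected, a number 0.30 log units lower from compound 3 to compound 4 (within the scatter). For compound 4 the estimated value in this assay is 1.1, with a range from 0.7 to 1.5.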

Compound 4, distribution coefficient: 1.1
For compound 4 middle estimate and measured number coincide at the digits printed; low and high end bracket the measured number.
By their numbers in this assay, from the lowest: compounds 2, 4, 1 and 3 (each within the scatter of the next, the first and the last beyond it).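

With its fluorine, compound 4 stands within the scatter of all three earlier compounds in this assay (a number 0.30 log units lower from compound 3 to compound 4 (within the scatter); a number 0.30 log units higher from compound 2 to compound 4 (within the scatter); a number 0.10 log units lower from compound 1 to compound 4 (within the scatter)). The earlier compounds had shown that a change on an oxygen on an aromatic ring can carry the number beyond the scatter, as between compound 2 and compound 3, whereas 5-fluoro-3-methylpyridin-2-yl cannot be separated from either of those two groups. Nothing available here accounts for these numbers.

The groups shown are all pyridinyl rings bearing chlorine, methyl or fluorine, so it stays open how an amine or a methoxy group on that ring, or a plain phenyl ring in its place, would read in this assay at this position. As far as these compounds go, it also stays open how 5-fluoropyridin-2-yl, without the methyl, would compare with compound 4.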